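Compound 4: trifluoromethoxy in place of fluoro

A few compounds are considered here, and "the series" means these few. Any claim that something is new, unique, unknown or untested is made for them only; others in the source may bear on it.

Compound 1 `Cc1cc(=O)oc2cc(OCC(=O)c3ccc(OC(F)(F)F)cc3)ccc12` gives > 100000 nM
Compound 2 `O=C(COc1ccc2c(C(F)(F)F)cc(=O)oc2c1)c1ccccc1` gives "not active" (no number reported)
Compound 3 `O=C(COc1ccc2c(C(F)(F)F)cc(=O)oc2c1)c1ccc(F)cc1` gives "not active" (no number reported)

In a functional assay on MCF7 cells (Homo sapiens) for antiproliferative activity, with a stated time of 96 h (on this read-out lower numbers stand for stronger inhibition and higher numbers for weaker inhibition), compound 3 is reported as "not active" (no number reported) and has no single number, as is also the case for compound 2. Compound 4 `O=C(COc1ccc2c(C(F)(F)F)cc(=O)oc2c1)c1ccc(OC(F)(F)F)cc1` is still unmeasured. The change trifluoromethoxy in place of fluoro on an aromatic carbon puts trifluoromethoxy in place of fluoro on an aromatic carbon. Among the measured compounds shown here, no measured step exists, so the data give no size of step to draw on. In this assay no step beyond the scatter is expected. That expectation rests on compound 1, which also carries trifluoromethoxy and whose entry > 100000 nM is a limit. For compound 4 the estimated value is 60000 nM with an expected range of 10000 nM to 200000 nM on this read-out.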

Compound 4, half-maximal inhibitory concentration: "not active" (no number reported)
The entry for compound 4 holds no number; no gap can be computed for the estimate.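

Compound 3 and compound 4 are both reported as not active, without a number, in this assay, so no step can be read between them. The compounds shown leave open whether any group at this place gives a measurable value in this assay.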